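Adding an Isopropoxy Group to Compound 3

The source may report more compounds than this note shows. Statements on the series, on what has been measured and on what is new or still open speak of the compounds shown alone.

Compound 1 `COc1cc(-n2ncnc2-c2ccc(C)cc2)cc(OC)c1OC`: 300 nM
Compound 2 `COc1cc(-n2ncnc2-c2ccc(Cl)cc2)cc(OC)c1OC`: > 10000 nM, a limit
Compound 3 `COc1cc(-n2ncnc2-c2ccccc2)cc(OC)c1OC`: > 10000 nM, a limit

In a functional assay on Jurkat cells (Homo sapiens) for antiproliferative activity, read by MTT assay, with a stated time of 72 h (on this read-out lower numbers stand for stronger inhibition and higher numbers for weaker inhibition), compound 3 gives > 10000 nM, which is a limit and not a number. Compound 4 `COc1cc(-n2ncnc2-c2ccc(OC(C)C)cc2)cc(OC)c1OC` differs from it by isopropoxy in place of hydrogen on an aromatic carbon, para to a large group. Within the data shown here, two measured steps bear on this change, an at least 33-fold higher number from compound 1 to compound 3 (1.52 log units; beyond the scatter) and an at least 33-fold higher number from compound 1 to compound 2 (1.52 log units; beyond the scatter). Both are large and beyond the scatter, yet only the methyl of compound 1 gives a measured number, and the chloro of compound 2 goes against any general gain from substitution. A moderate to large move towards stronger inhibition is therefore expected, with real uncertainty, as an at least 8.3-fold lower number from compound 3 to compound 4 (0.92 log units; beyond the scatter). The estimate for compound 4 is 1200 nM, within an expected range of 150 nM to 10000 nM.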

Compound 4, half-maximal inhibitory concentration: 650 nM
Beside the measured number, compound 4's estimate is 1.8-fold (0.27 log units) above it, and the stated range covers the measured number.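

In this assay, isopropoxy para to a large group gives an at least 15-fold lower number from compound 3 to compound 4 (1.18 log units; beyond the scatter) and an at least 15-fold lower number from compound 2 to compound 4 (1.18 log units; beyond the scatter). A measured number at this place is therefore not confined to methyl, although methyl keeps a lead, with a 2.2-fold higher number from compound 1 to compound 4 (0.34 log units; beyond the scatter), and the chloro of compound 2 shows that not every group there gives such a number. Both large steps start from a limit, so their true size stays unknown: the limit of > 10000 nM in this assay, at which 2 of the 4 values shown sit.

The compounds shown leave open whether an amine, a carboxylic acid or a longer chain at this place would give a measured number. They also leave open whether any group there goes beyond methyl.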